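This account rests on a few compounds, and the source may have more. Where it says the series, first, only, none or still open, it means among the compounds named here.

Working notes on the series. In an ADME assay on MRC5 cells (Homo sapiens) for cytotoxicity, read by fluorescence and resazurin assay, with a stated time of 3 days (on this read-out lower numbers stand for stronger inhibition and higher numbers for weaker inhibition), compound 1 `Cc1cn(C2CCN(Cc3cccc(Oc4ccc(Cl)cc4)c3)CC2)c(=O)[nH]c1=O` gives 25100 nM. Compound 2 `Cc1cn(C2CCN(Cc3cccc(Oc4ccccn4)c3)CC2)c(=O)[nH]c1=O` gives > 64000 nM, which is a limit of the assay and not a number. Compound 3 `Cc1cn(C2CCN(Cc3cccc(Oc4ccccc4)c3)CC2)c(=O)[nH]c1=O` has no number to offer, as its result reads "not determined" (no result reported), so it gives no starting value for the next step.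

Compound 4 `Cc1cn(C2CCN(Cc3cccc(Oc4cc(F)cc(F)c4)c3)CC2)c(=O)[nH]c1=O` differs from compound 3 as follows: 3,5-difluorophenyl in place of phenyl on an oxygen on an aromatic ring. That is, 3,5-difluorophenyl takes the place of phenyl on an oxygen on an aromatic ring.

Among the measured compounds shown here, one measured step bears on this, at the same place: an at least 2.5-fold higher number from compound 1 to compound 2 (0.40 log units; beyond the scatter). It brings in pyridin-2-yl, whereas compound 4 keeps a ring of carbon only, as compound 1 does. With no value for compound 3, no size or direction can be set for the step to compound 4. The expectation therefore leans on compound 1 at 25100 nM, and a number in that region is expected. A limit of the assay remains possible for compound 4.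

For compound 4 the estimate is 30000 nM, with an expected range of 12000 nM to 64000 nM.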

Compound 4, half-maximal inhibitory concentration: > 64000 nM
Compound 4: only a limit was reported; the forecaster's own chance of this, stated with the estimate: 30%; middle value at least 2.1-fold (0.32 log units) away from the limit.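

At this place, on an oxygen on an aromatic ring, a ring of carbon only can also raise the number in this assay: 3,5-difluorophenyl in place of 4-chlorophenyl gives an at least 2.5-fold higher number from compound 1 to compound 4 (0.40 log units; beyond the scatter). The earlier rise with pyridin-2-yl therefore no longer stands alone, and a ring nitrogen is not needed for a rise of this kind in the pair shown. The step from compound 2 to compound 4 cannot be read, since both end at the same limit of the assay and neither gives a number: the limit of > 64000 nM in this assay, at which 2 of the 4 values shown sit.

As far as these compounds go, with no result for compound 3, it stays open how plain phenyl compares with either substituted ring. Also open, from the compounds shown here alone, is whether an amine or a carboxylic acid on this ring would give a number or another limit.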